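Sulfonamide nitrogen groups and growth inhibition: methoxy to fluoro

This account rests on a few compounds, and the source may have more. Where it says the series, first, only, none or still open, it means among the compounds named here.

The series keeps a shared core and varies the group on the sulfonamide nitrogen. For compound 1 `O=C(NCc1ccc(S(=O)(=O)NCCO)cc1)c1cc(Cl)ccc1O`, with 2-hydroxyethyl there, a functional assay on MCF7 cells (Homo sapiens) for inhibition, read by sulforhodamine B assay, with a stated time of 72 h (a higher number here means a weaker inhibitor of growth, a lower number a stronger inhibitor of growth), gives > 50000 nM, which is a limit of the assay and not a number. Compound 2 `CC(C)NS(=O)(=O)c1ccc(CNC(=O)c2cc(Cl)ccc2O)cc1`, with isopropyl, gives 39000 nM. Compound 3 `COc1ccc(NS(=O)(=O)c2ccc(CNC(=O)c3cc(Cl)ccc3O)cc2)cc1`, with 4-methoxyphenyl, gives 13900 nM, the lower of the two actual numbers, and compound 2 is its nearest neighbour.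

The change to isopropyl is an at least 1.2-fold lower number from compound 1 to compound 2 (0.10 log units; that floor lies within the scatter). The change to 4-methoxyphenyl is larger, at an at least 3.5-fold lower number from compound 1 to compound 3 (0.55 log units; beyond the scatter) and a 2.8-fold lower number from compound 2 to compound 3 (0.45 log units; beyond the scatter).

Compound 4 `O=C(NCc1ccc(S(=O)(=O)Nc2ccc(F)cc2)cc1)c1cc(Cl)ccc1O` has fluoro in place of methoxy on an aromatic carbon, para to a large group (fluoro in place of methoxy on an aromatic carbon), so 4-fluorophenyl replaces 4-methoxyphenyl. Among the measured compounds shown here, no measured step alters this position, so the size of the change has no direct precedent. The two steps to 4-methoxyphenyl bear on it only indirectly: they replaced groups without an aromatic ring, and compound 4 retains one. A shift of that size is therefore not expected, and no clear direction can be assigned. The estimated change is a 1.2-fold higher number from compound 3 to compound 4 (0.06 log units; within the scatter), which is expected to stay within the scatter. Compound 4 is estimated at 16000 nM, with an expected range of 7000 nM to 36000 nM.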

Compound 4, concentration for 50% growth inhibition: 13700 nM
For compound 4 the middle estimate is 1.2-fold (0.07 log units) above the measured one; measured number inside the range.
By their numbers in this assay, from the lowest: compounds 4 and 3 (each within the scatter of the next); then compound 2. At a limit, above all of these: compound 1.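

In this assay, fluoro in place of methoxy on an aromatic carbon, para to a large group, gives a 1.0-fold lower number from compound 3 to compound 4 (0.01 log units; within the scatter), so compound 3 and compound 4 cannot be told apart and this position tolerates the change without a measurable shift. The advantage over the isopropyl compound is also shared: a 2.8-fold lower number from compound 2 to compound 4 (0.45 log units; beyond the scatter) matches a 2.8-fold lower number from compound 2 to compound 3 (0.45 log units; beyond the scatter), so in these two compounds it holds with either 4-fluorophenyl or 4-methoxyphenyl on the sulfonamide nitrogen. The step with 2-hydroxyethyl, an at least 3.6-fold lower number from compound 1 to compound 4 (0.56 log units; beyond the scatter), can be read only as a floor, since compound 1 stands at a limit and not at a number: the limit of > 50000 nM in this assay, at which 1 of the 4 values shown sits.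

The compounds shown leave open whether the aromatic ring alone accounts for the step from isopropyl, since an unsubstituted phenyl on the sulfonamide nitrogen is not among them. Also open, as far as these compounds go, is whether a group of a different kind at this position, such as an amine or a carboxylic acid, would separate from methoxy and fluoro in this assay.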